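The source may hold more compounds than are shown below. What is called first, only, known or untested is meant among the compounds shown, and "the series" means these compounds.

In a functional assay on MCF7 cells (Homo sapiens) for inhibition, read by MTT assay, with a stated time of 48 h (a higher number here means a weaker inhibitor, a lower number a stronger inhibitor), compound 3 `CCOC(=O)C1=C(N/N=C(/Br)c2ccccc2)Nc2[nH]nc(C)c2C1c1ccc(N(C)C)cc1` gives 78400 nM as the highest number of the three measured, against compound 1 `CCOC(=O)C1=C(NN=C(C(C)=O)C(C)=O)Nc2[nH]nc(C)c2C1c1ccc(N(C)C)cc1` with 9740 nM and compound 2 `CCOC(=O)C1=C(NN=C(C#N)C#N)Nc2[nH]nc(C)c2C1c1ccc(N(C)C)cc1` with 12100 nM on the same read-out. Compound 4 `CCOC(=O)C(=NNC1=C(C(=O)OCC)C(c2ccc(N(C)C)cc2)c2c(C)n[nH]c2N1)C(=O)OCC` differs from compound 3 by a group of 12 heavy atoms (7 carbon, 1 nitrogen, 4 oxygen; no ring) in place of a group of 9 heavy atoms (7 carbon, 1 nitrogen, 1 bromine; one six-membered aromatic ring of carbon only), on an amine nitrogen and its entering group has no ring, as in compound 1 and compound 2. Among the measured compounds shown here, two steps bear on this, namely an 8.0-fold higher number from compound 1 to compound 3 (0.91 log units; beyond the scatter) and a 6.5-fold higher number from compound 2 to compound 3 (0.81 log units; beyond the scatter) and both end at the ring-bearing group, whereas a 1.2-fold higher number from compound 1 to compound 2 (0.09 log units; within the scatter) joins the two ringless groups. For the measured compounds named here, no measured compound carries this exact group, yet in this assay a modest move to a lower number is expected, namely a 5.6-fold lower number from compound 3 to compound 4 (0.75 log units; beyond the scatter) on this reasoning. The estimate for compound 4 is 14000 nM with an expected range from 5000 nM to 45000 nM.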

Compound 4, half-maximal inhibitory concentration: 89800 nM
The estimate for compound 4 lay 6.4-fold (0.81 log units) below the measured number; the measured number lies above the stated range.
By their numbers in this assay, from the lowest: compounds 1 and 2 (each within the scatter of the next); then compounds 3 and 4 (each within the scatter of the next).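

In this assay, the step of a 1.1-fold higher number from compound 3 to compound 4 (0.06 log units; within the scatter) lies within the scatter, so having no ring in the group on this amine nitrogen does not separate compound 4 from compound 3. Ringless groups at this position can therefore differ beyond the scatter, as shown by a 7.4-fold higher number from compound 2 to compound 4 (0.87 log units; beyond the scatter) and by a 9.2-fold higher number from compound 1 to compound 4 (0.96 log units; beyond the scatter) in the same read-out. No measurement given here accounts for this difference. Going by these compounds, it remains open whether a ringless group ending in a carboxylic acid on this amine nitrogen would stand with compound 1 and compound 2 or with compound 3 and compound 4.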